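The compounds below may be only part of what the source reports. "The series", "measured", "known", "first", "only" and "open" are said of these compounds alone.

Compound 1, `CCCNC(=O)N1CCN(c2cc(N)c3cc(OC)c(OC)cc3n2)CC1`, gives 0.44 nM in an assay on brain for displacement of a labelled ligand from Adrenergic receptor alpha-1 (Rattus norvegicus); on this read-out lower numbers stand for stronger inhibition and higher numbers for weaker inhibition.
Compound 2, `COc1cc2nc(N3CCN(c4ccccc4)CC3)cc(N)c2cc1OC`, gives 1.72 nM in this assay.
Compound 3, `COc1cc2nc(N3CCN(C(=O)c4ccco4)CC3)cc(N)c2cc1OC`, gives 0.14 nM in this assay.

Compound 3 has the lowest number of the three, that is, the strongest binding: compound 1 stands nearest, with a 3.1-fold lower number from compound 1 to compound 3 (0.50 log units; beyond the scatter), and compound 2 furthest, with a 12-fold lower number from compound 2 to compound 3 (1.09 log units; beyond the scatter). Compound 4, `COc1cc2nc(N3CCN(C(C)=O)CC3)cc(N)c2cc1OC`, differs from compound 3 in one place: methyl in place of furan-2-yl on a carbonyl carbon. The group that sits on the carbonyl carbon is thus exchanged again, as it was between compound 1 and compound 3, where a 3.1-fold lower number from compound 1 to compound 3 (0.50 log units; beyond the scatter) came with the entry of the furan-2-yl group. Its removal in favour of methyl is therefore expected to move the number back up, by a modest step rather than a large one, since the step of a 12-fold lower number from compound 2 to compound 3 (1.09 log units; beyond the scatter) concerned a larger exchange. For compound 4 a modest rise in this assay is expected, a 3.6-fold higher number from compound 3 to compound 4 (0.55 log units; beyond the scatter), giving an estimate of 0.5 nM with a range from 0.15 nM to 1.6 nM.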

Compound 4, inhibition constant: 1.17 nM
For compound 4 the middle estimate is 2.3-fold (0.37 log units) below the measured one, and the stated range covers the measured number.
By their numbers in this assay, from the lowest: compound 3; then compound 1; then compounds 4 and 2 (each within the scatter of the next).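

On the carbonyl carbon, the exchange of furan-2-yl for methyl gives an 8.4-fold higher number from compound 3 to compound 4 (0.92 log units; beyond the scatter) in this assay and the exchange of propylamino for methyl gives a 2.7-fold higher number from compound 1 to compound 4 (0.42 log units; beyond the scatter) in the same read-out, so these compounds rank the three groups on this carbon as furan-2-yl, then propylamino, then methyl, from the lowest number to the highest. A carbonyl on the amine nitrogen does not by itself secure a low number: with a 1.5-fold lower number from compound 2 to compound 4 (0.17 log units; within the scatter) acetyl cannot be told apart from phenyl at that nitrogen.

From the compounds shown here alone, whether the low number depends on furan-2-yl in particular, or would also come with another ring or a longer chain on the carbonyl carbon, such as phenyl, thiophen-2-yl or propyl, stays open. Nothing measured here explains these differences.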